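This account rests on a few compounds, and the source may have more. Where it says the series, first, only, none or still open, it means among the compounds named here.

Among the measured compounds shown here, in a functional assay on HCT-116 cells (Homo sapiens) for cytotoxicity, read by MTT assay, with a stated time of 48 h, in the presence of a further agent that is not named here (on this read-out lower numbers stand for an effect already at smaller amounts and higher numbers for an effect only at larger amounts of compound), compound 3 (`CC(C)c1cc(NNC(=O)Nc2cc(Cl)nc(Cl)c2)nc2c1cnn2C`) gives 17200 nM and holds the second highest of the three numbers so far. Compound 1 (`Cn1ncc2c(-c3ccccc3)cc(NNC(=O)Nc3cc(Cl)nc(Cl)c3)nc21`) is lower with 6240 nM and compound 2 (`Cn1ncc2c(-c3ccc(F)cc3)cc(NNC(=O)Nc3cc(Cl)nc(OCCF)c3)nc21`) is higher with 37200 nM on the same read-out. Compound 4 (`Cn1ncc2c(-c3ccc(F)cc3)cc(NNC(=O)Nc3cc(Cl)nc(Cl)c3)nc21`) has 4-fluorophenyl in place of isopropyl on an aromatic carbon. For the measured compounds named here, the one measured step that bears on this is isopropyl in place of phenyl (a 2.8-fold higher number from compound 1 to compound 3 (0.44 log units; beyond the scatter)), a modest change that runs the opposite way. Going by the values given here, compound 2 also carries 4-fluorophenyl but differs elsewhere, so it offers no direct step. A modest step towards a lower number is therefore expected in this assay (a 2.6-fold lower number from compound 3 to compound 4 (0.42 log units; beyond the scatter)). Compound 4 is estimated at 6500 nM (expected range 2500 nM to 16000 nM).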

Compound 4, half-maximal effective concentration: 8210 nM
Compound 4: middle estimate off by 1.3-fold (0.10 log units), on the low side; low and high end bracket the measured number.
By their numbers in this assay, from the lowest: compounds 1 and 4 (each within the scatter of the next); then compound 3; then compound 2.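

In this assay a second aromatic ring at this carbon reads like the first: a 2.1-fold lower number from compound 3 to compound 4 (0.32 log units; beyond the scatter) runs the same way as the earlier comparison of phenyl with isopropyl, while a 1.3-fold higher number from compound 1 to compound 4 (0.12 log units; within the scatter) leaves fluoro in place of hydrogen on that ring within the scatter. Among the compounds shown here, at the other changed place, a 4.5-fold lower number from compound 2 to compound 4 (0.66 log units; beyond the scatter) gives the first single-place reading of chloro against 2-fluoroethoxy, with chloro on the lower side. No measured evidence accounts for these steps.

Open, as far as these compounds go, is how a saturated ring such as cyclohexyl would read at this carbon, or an amine such as morpholine in place of the chloro.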